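Cyclopropyl to methyl on the sulfonyl sulfur: plasma binding

A few compounds are considered here, and "the series" means these few. Any claim that something is new, unique, unknown or untested is made for them only; others in the source may bear on it.

Compound 1 `Cn1cc(-c2ccc(C(F)(F)F)cc2)c2cc(F)c(C(=O)NS(=O)(=O)C3CC3)cc21` was measured in an ADME assay on a cell-free system (plasma, Mus musculus) for protein binding (on this read-out lower numbers stand for a smaller free fraction and higher numbers for a larger free fraction), and gave 0.0035. Compound 2 `CC(C)COc1ncc(-c2cn(C)c3cc(C(=O)NS(=O)(=O)C4CC4)c(F)cc23)cc1Cl` gave 0.002 in this assay, and compound 3 `CC(C)COc1ncc(-c2cn(C)c3cc(C(=O)NS(C)(=O)=O)c(F)cc23)cc1Cl` gave 0.002. How the core of compound 1 differs from the core of compound 2 is not broken down here. Compound 3 arises from compound 2 by methyl in place of cyclopropyl on a sulfonyl sulfur, and this assay shows no change at the digits printed from compound 2 to compound 3 (within the scatter). Compound 4 `Cn1cc(-c2ccc(C(F)(F)F)cc2)c2cc(F)c(C(=O)NS(C)(=O)=O)cc21` arises from compound 1 by the same change, (methyl in place of cyclopropyl on a sulfonyl sulfur), and has not yet been measured in this assay. Since compound 2 and compound 3 sit together within the scatter, the step from compound 1 to compound 4 is expected to be small as well, no change at the digits printed from compound 1 to compound 4 (within the scatter). For compound 4 the estimate in this assay is therefore 0.0035, with a range from 0.002 to 0.006.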

Compound 4, unbound fraction: 0.005
For compound 4 the middle estimate is 1.4-fold (0.15 log units) below the measured one; low and high end bracket the measured number.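

In this assay, methyl in place of cyclopropyl on a sulfonyl sulfur gives a 1.4-fold higher number from compound 1 to compound 4 (0.15 log units; within the scatter). Set beside the earlier step, the change carries over from one core to the other without a detectable difference: the same change on two cores in this assay, no change at the digits printed (within the scatter) from compound 2 to compound 3 and a 1.4-fold higher number (0.15 log units; within the scatter) from compound 1 to compound 4, 1.4-fold (0.15 log units) apart, within the scatter of two such steps This shows only that the step stays within the scatter on these two cores; it does not show that the same would hold on any other core, and since neither step is beyond the scatter, it gives no size of an effect to transfer.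

Open, as far as these compounds go, is whether a longer chain or an amine on the sulfonyl sulfur would behave the same way. Also open, from the compounds shown here alone, is what a carboxylic acid in place of the (methylsulfonyl)carbamoyl group would do to the unbound fraction.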